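The source may hold more compounds than are shown below. What is called first, only, known or untested is meant among the compounds shown, and "the series" means these compounds.

Compound 1 `Nc1nc2ccccn2c1-c1ccc(O)cc1`: > 100000 nM; compound 2 `CNc1nc2ccccn2c1-c1ccc(O)cc1`: > 100000 nM; compound 3 `Nc1nc2cc(C(F)(F)F)ccn2c1-c1ccc(O)cc1`: > 100000 nM.

In an assay on isolated protein for inhibition of ubiquitin carboxyl-terminal hydrolase 47 (Homo sapiens) (a higher number here means a weaker inhibitor, a lower number a stronger inhibitor), compound 1 gives only a limit, > 100000 nM. Compound 2 likewise gives only a limit, > 100000 nM. Compound 3 also gives only a limit, > 100000 nM. The step that the two limits leave unreadable from compound 1 to compound 2 and the step that the two limits leave unreadable from compound 1 to compound 3 are therefore both unreadable, since (the limit of > 100000 nM in this assay, at which 3 of the 3 values shown sit).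

Compound 4 `Cc1ccc2nc(N)c(-c3ccc(O)cc3)n2c1` differs from compound 1 by methyl in place of hydrogen on an aromatic carbon. Neither measured step can size this change, but every value shown sits at the limit, and a methyl on the core of compound 1 is not expected to move the read-out out of that region. Compound 4 is therefore expected to give 100000 nM, in the range 30000 nM to 300000 nM, a step of a number no higher from compound 1 to compound 4 (the limit leaves the size open) that is estimated to be within the scatter.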

Compound 4, half-maximal inhibitory concentration: > 100000 nM
Compound 4 gave a limit, no number; the forecaster's own chance of this, stated with the estimate: 85%; the middle value lies on the limit itself.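

For the compounds shown here, compound 4, like compound 1, gives only a limit, so no step between them can be read: (the limit of > 100000 nM in this assay, at which 4 of the 4 values shown sit). In this assay the compounds shown leave open whether any change to the shared core yields a measurable inhibition.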